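The source may report more compounds than this note shows. Statements on the series, on what has been measured and on what is new or still open speak of the compounds shown alone.

Working notes on the series.

Compound 3 `O=C(NCc1ccc(S(=O)(=O)N2CCCCC2)cc1)c1cnc2nccn2c1` sits second highest of the three numbers in an ADME assay on microsomes from liver (Homo sapiens) for metabolic stability, read by LC-MS, with a stated time of 30 min, tested at 1 uM; a higher number here means that more of the compound is left, a lower number that less of the compound is left: compound 3 gives 64%. Compound 1 `O=C(NCc1ccc(S(=O)(=O)c2cc(F)cc(F)c2)cc1)c1cc2ccncc2o1` lies nearest; in this assay compound 1 gives 77%, a number beyond the scatter above compound 3. Compound 2 `O=C(NCc1ccc(S(=O)(=O)N2CCCCC2)cc1)c1cc2ccncc2[nH]1` lies furthest; in this assay compound 2 gives 50%, beyond the scatter below compound 3. Going by the values given here, the one measured step, a number 14 percentage points higher from compound 2 to compound 3 (beyond the scatter), swaps the bicyclic group on the carbonyl carbon and is modest.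

Compound 4 `O=C(NCc1ccc(S(=O)(=O)N2CCCCC2)cc1)c1cc2ccncc2o1` differs from compound 3 in the same place: a group of 9 heavy atoms (7 carbon, 1 nitrogen, 1 oxygen; one five-membered aromatic ring with 1 hetero atom, one six-membered aromatic ring with 1 hetero atom) in place of a group of 9 heavy atoms (6 carbon, 3 nitrogen; one five-membered aromatic ring with 2 hetero atoms, one six-membered aromatic ring with 2 hetero atoms), on a carbonyl carbon. Among the compounds with values here, the entering group is the one carried by compound 1, but compound 1 differs from compound 4 elsewhere, so its value only hints at the outcome. With a single bicyclic-group step of modest size, a step of similar size, in either direction or none beyond the scatter, is expected. The estimate for compound 4 in this assay is 66%, within 48% to 82%, an expected step of a number 2 percentage points higher from compound 3 to compound 4 (within the scatter).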

Compound 4, percent of the compound remaining: 56%
Compound 4: the middle estimate sits 10 percentage points above what was measured, within the range that was stated.
By their numbers in this assay, from the lowest: compounds 2, 4 and 3 (each within the scatter of the next, the first and the last beyond it); then compound 1.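

In this assay, the group entering on the carbonyl carbon does not separate from either of the other two bicyclic groups on the piperidin-1-yl sulfonyl compounds (a number 8 percentage points lower from compound 3 to compound 4 (within the scatter); a number 6 percentage points higher from compound 2 to compound 4 (within the scatter)). Among these three groups, only compounds 2 and 3 remain beyond the scatter of each other, so the position shows a limited spread and no clear order of all three. With the carbonyl group held constant, the change on the sulfonyl sulfur, piperidin-1-yl in place of 3,5-difluorophenyl, is beyond the scatter (a number 21 percentage points lower from compound 1 to compound 4 (beyond the scatter)), so the value of compound 1 does not follow from its carbonyl group alone. No supporting data speak to the reason for these steps.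

On these data alone, whether 3,5-difluorophenyl holds its value with the other two bicyclic groups remains open. As far as these compounds go, how morpholin-4-yl on the sulfonyl sulfur would read is also open.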